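This account rests on a few compounds, and the source may have more. Where it says the series, first, only, none or still open, it means among the compounds named here.

Measured compounds:
- compound 1, `COc1cc2c(Nc3nc4ccc(C(=O)Nc5c(C)cccc5Cl)cc4s3)ncnc2cc1OCCCN1CCC(C)CC1`, 9700 nM in a functional assay on A549 cells (Homo sapiens) for cytotoxicity, read by WST assay, with a stated time of 72 h; a higher number here means a weaker inhibitor, a lower number a stronger inhibitor
- compound 2, `COc1cc2c(Nc3nc4ccc(C(=O)Nc5c(C)cccc5Cl)cc4s3)ncnc2cc1OCCCN1CCCC1`, 38600 nM
- compound 3, `COc1cc2c(Nc3nc4ccc(C(=O)Nc5c(C)cccc5C)cc4s3)ncnc2cc1OCCCN1CCCCC1C`, 75700 nM

Compound 3 shows the highest number of the three in this assay. Its nearest neighbour is compound 2, which is within the scatter of it, while compound 1 lies clearly lower, beyond the scatter.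

Compound 4, `COc1cc2c(Nc3nc4ccc(C(=O)Nc5c(C)cccc5Cl)cc4s3)ncnc2cc1OCCCN1CCCCC1C`, is not yet measured. It differs from compound 3 in one place: chloro in place of methyl on an aromatic carbon. Among the measured compounds shown here, the only measured step, a 4.0-fold higher number from compound 1 to compound 2 (0.60 log units; beyond the scatter), concerns a different part of the molecule, the amine at the end of the chain, and so gives no direct guide to a chloro for methyl swap. Compounds 1 and 2 do carry the chloro, and both give lower numbers than compound 3, but each also differs from compound 3 at the amine, so the two changes cannot be separated.

Compound 4 is therefore expected near compound 3, with the step of a 1.9-fold lower number from compound 3 to compound 4 (0.28 log units; within the scatter) estimated as a modest move to a lower number, giving an estimate of 40000 nM within 12000 nM to 120000 nM.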

Compound 4, half-maximal inhibitory concentration: 6700 nM
Compound 4: the middle estimate sits 6.0-fold (0.78 log units) above what was measured, and the stated range ends above it.
By their numbers in this assay, from the lowest: compounds 4 and 1 (each within the scatter of the next); then compounds 2 and 3 (each within the scatter of the next).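

In this assay, among the compounds shown here, chloro in place of methyl on an aromatic carbon ortho to a large group gives an 11-fold lower number from compound 3 to compound 4 (1.05 log units; beyond the scatter) with the amine held constant, so this single-atom swap has a large effect that the earlier compounds, which also differed at the amine, could not isolate. With chloro now fixed, the amine can be compared too: 2-methylpiperidin-1-yl in place of pyrrolidin-1-yl gives a 5.8-fold lower number from compound 2 to compound 4 (0.76 log units; beyond the scatter) and in place of 4-methylpiperidin-1-yl gives a 1.4-fold lower number from compound 1 to compound 4 (0.16 log units; within the scatter), so the two methylpiperidines are not separated here. Nothing available here explains the effect of the chloro.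

As far as these compounds go, whether the swap has the same effect with the pyrrolidine or 4-methylpiperidine amines remains open. So does how fluoro, bromo or methoxy at this carbon, or an open-chain amine such as dimethylamino, would compare.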